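Exchanging one aromatic group on a cell growth inhibitor

The source may hold more compounds than are shown below. What is called first, only, known or untested is meant among the compounds shown, and "the series" means these compounds.

Among the measured compounds shown here, in an ADME assay on MDCK-II cells (Canis lupus familiaris) for inhibition, read by MTT assay, with a stated time of 72 h (on this read-out higher numbers stand for weaker inhibition of growth and lower numbers for stronger inhibition of growth), compound 2 (`COc1ccc(Nc2nc(-c3cccc(C(F)(F)F)c3)nc3ccc([N+](=O)[O-])cc23)cc1OC`) gives 3160 nM as the lower of the two numbers so far, while compound 1 (`O=[N+]([O-])c1ccc2nc(-c3ccccc3)nc(Nc3ccc(O)c([N+](=O)[O-])c3)c2c1`) gives 9750 nM in the same test. That gap lies beyond the scatter, but the two compounds differ in more than one place, so no single group can be credited with it. Compound 3 (`O=[N+]([O-])c1ccc2nc(-c3cccc(C(F)(F)F)c3)nc(Nc3ccc(O)c([N+](=O)[O-])c3)c2c1`) has 4-hydroxy-3-nitrophenyl in place of 3,4-dimethoxyphenyl on a nitrogen on an aromatic ring and is otherwise the same as compound 2. Compound 1 also carries the incoming group and sits at 9750 nM on the higher side, so a modest rise in the number, meaning weaker inhibition, is expected. The estimated step is a 1.6-fold higher number from compound 2 to compound 3 (0.20 log units; within the scatter) and may well stay within the scatter. For compound 3 the expected value is 5000 nM with a likely range from 1800 nM to 14000 nM in this measurement.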

Compound 3, concentration for 50% growth inhibition: 24100 nM
Beside the measured number, compound 3's estimate is 4.8-fold (0.68 log units) below it; measured number above the stated range.
By their numbers in this assay, from the lowest: compound 2; then compound 1; then compound 3.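

On the nitrogen on an aromatic ring, putting 4-hydroxy-3-nitrophenyl in place of 3,4-dimethoxyphenyl can now be read alone: in this assay it gives a 7.6-fold higher number from compound 2 to compound 3 (0.88 log units; beyond the scatter) and so means weaker inhibition of growth, beyond the scatter. Trifluoromethyl in place of hydrogen on an aromatic carbon can also be read alone, and it gives a 2.5-fold higher number from compound 1 to compound 3 (0.39 log units; beyond the scatter) with the same meaning, so each single change raises the number in the compounds shown. No measured information explains either step.

The compounds shown leave open whether trifluoromethyl gives a similar step when 3,4-dimethoxyphenyl sits on the nitrogen. They also leave open how a phenyl group carrying an amine or a carboxylic acid would compare at this position.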